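The compounds below may be only part of what the source reports. "The series", "measured", "known", "first", "only" and "open" are said of these compounds alone.

Measured compounds:
compound 1, `Nc1ccc(/C=C2\SC(=O)N(Cc3ccc(C(F)(F)F)cc3)C2=O)cc1`, 134000 nM
compound 2, `Nc1ccc(/C=C2\SC(=O)N(Cc3ccc(Cl)cc3)C2=O)cc1`, 60000 nM
compound 3, `Nc1cccc(/C=C2\SC(=O)N(Cc3ccc(C(F)(F)F)cc3)C2=O)c1`, > 250000 nM

All three share one core and were tested in a functional assay on FM3A cells (Mus musculus) for cytotoxicity, read by cell counting, with a stated time of 2 days; a lower number here means a stronger inhibitor, a higher number a weaker inhibitor. Compound 1 gives 134000 nM. Compound 2 gives 60000 nM. Compound 3 gives > 250000 nM, which is a limit of the assay and not a number.

Two changes connect these compounds. The first, (chloro in place of trifluoromethyl on an aromatic carbon), produces a 2.2-fold lower number from compound 1 to compound 2 (0.35 log units; beyond the scatter). The second, (3-aminophenyl in place of 4-aminophenyl on a double-bonded chain carbon bound to a double-bonded ring carbon), produces an at least 1.8-fold higher number from compound 1 to compound 3 (0.27 log units; that floor lies within the scatter); this step rests on (the limit of > 250000 nM in this assay, at which 1 of the 3 values shown sits), so only its floor is known.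

Compound 4, `Nc1cccc(/C=C2\SC(=O)N(Cc3ccc(Cl)cc3)C2=O)c1`, is not yet measured. It differs from compound 3 by chloro in place of trifluoromethyl on an aromatic carbon, the same change as that from compound 1 to compound 2, made on the core of compound 3 instead of the core of compound 1. If the change carries over, one would expect a step of about an at least 1.2-fold lower number from compound 3 to compound 4 (0.09 log units; that floor lies within the scatter), resting on a 2.2-fold lower number from compound 1 to compound 2 (0.35 log units; beyond the scatter). Because compound 3 only gives > 250000 nM, the starting point for compound 4 is itself uncertain, and a value that again falls outside the measured range cannot be excluded. Compound 4 is therefore estimated at 200000 nM in this assay, with a range of 70000 nM to 600000 nM.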

Compound 4, half-maximal inhibitory concentration: 246000 nM
Compound 4: middle estimate off by 1.2-fold (0.09 log units), on the low side; measured number inside the range.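

In this assay compound 3 gives > 250000 nM, which is a limit of the assay and not a number. Chloro in place of trifluoromethyl can therefore be read on this core only as a floor, an at least 1.0-fold lower number from compound 3 to compound 4 (0.00 log units; that floor lies within the scatter), so the result neither shows that the change carries over from the other core with the same size nor shows that it fails to do so: the same change on two cores in this assay, a 2.2-fold lower number (0.35 log units; beyond the scatter) from compound 1 to compound 2 and an at least 1.0-fold lower number (0.00 log units; that floor lies within the scatter) from compound 3 to compound 4; the limit leaves it open whether they differ. The change from 4-aminophenyl to 3-aminophenyl can now be read as a full step in the chloro pair, a 4.1-fold higher number from compound 2 to compound 4 (0.61 log units; beyond the scatter), which shows that it weakens the read-out there, while its size in the trifluoromethyl pair remains a floor, so equal size on the two cores is neither shown nor ruled out: the same change on two cores in this assay, an at least 1.8-fold higher number (0.27 log units; that floor lies within the scatter) from compound 1 to compound 3 and a 4.1-fold higher number (0.61 log units; beyond the scatter) from compound 2 to compound 4; the limit leaves it open whether they differ.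

The compounds shown leave open whether a group such as a methoxy group or a nitrile, in place of chloro or trifluoromethyl on that aromatic carbon, would shift the number in the same direction on both cores. They also leave open how an acetamide or a hydroxyl group in place of the amine would compare on either core.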